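Moving a Methyl Group on the Outer Ring: Cytotoxicity

The compounds below may be only part of what the source reports. "The series", "measured", "known", "first", "only" and "open" are said of these compounds alone.

compound 1, `COc1ccccc1-c1cc(C)c(Nc2ccnc(Nc3ccc(C#N)cc3)n2)c(C)c1`: in an ADME assay on MT4 cells (Homo sapiens) for cytotoxicity, read by MTT assay, with a stated time of 4 days (on this read-out lower numbers stand for higher toxicity in this test and higher numbers for lower toxicity in this test), compound 1 gives 940 nM
compound 2, `Cc1cccc(-c2cc(C)c(Nc3ccnc(Nc4ccc(C#N)cc4)n3)c(C)c2)c1`: compound 2 gives 3670 nM

Among the compounds with values here, of these two measured compounds, compound 2 has the higher number and so the lower toxicity in this test; its only neighbour is compound 1, and the step of a 3.9-fold higher number from compound 1 to compound 2 (0.59 log units; beyond the scatter) is the single comparison available. Compound 3, `Cc1ccc(-c2cc(C)c(Nc3ccnc(Nc4ccc(C#N)cc4)n3)c(C)c2)cc1`, has not been measured. It differs from compound 2 in one place: 4-methylphenyl in place of 3-methylphenyl on an aromatic carbon. Within the data shown here, the two compounds have the same atoms joined differently, and no measured step involves such a change alone; the one known step replaces a methoxyphenyl by a methylphenyl and does not bear directly on it. For compound 3 a step within the usual scatter is therefore expected, a 1.2-fold lower number from compound 2 to compound 3 (0.09 log units; within the scatter). The estimate for compound 3 is 3000 nM, with a range from 1200 nM to 8000 nM.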

Compound 3, half-maximal cytotoxic concentration: 5570 nM
Estimate against measurement, compound 3: 1.9-fold (0.27 log units) below, and the stated range covers the measured number.
By their numbers in this assay, from the lowest: compound 1; then compounds 2 and 3 (each within the scatter of the next).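

In this assay, putting 4-methylphenyl in place of 3-methylphenyl on this aromatic carbon gives a step within the usual scatter (a 1.5-fold higher number from compound 2 to compound 3 (0.18 log units; within the scatter)), so this assay does not separate the two arrangements of the methyl group. The step away from 2-methoxyphenyl is again beyond the scatter (a 5.9-fold higher number from compound 1 to compound 3 (0.77 log units; beyond the scatter)), so both methylphenyl compounds now stand apart from compound 1, although that change alters the group and where it sits together. No available evidence explains these numbers.

The compounds shown leave open whether 2-methylphenyl would match the other methylphenyl compounds or compound 1, which would help separate the effect of the group from that of its place. They also leave open how the cytotoxicity read-out would respond to an outer ring carrying an amine or a carboxylic acid.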